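Series notes: pyrazole-pyrimidine anilines, chain length at ring nitrogen

This account rests on a few compounds, and the source may have more. Where it says the series, first, only, none or still open, it means among the compounds named here.

Measured compounds:
compound 1 `Cn1nc(-c2ccnc(Nc3cccc([N+](=O)[O-])c3)n2)c2ccccc21` — 490 nM
compound 2 `CCn1nc(-c2ccnc(Nc3cccc([N+](=O)[O-])c3)n2)c2ccccc21` — 2820 nM
compound 3 `CCn1nc(-c2ccnc(Nc3ccc(O)cc3)n2)c2ccccc21` — 5290 nM

All three values come from a functional assay on HCT-116 cells (Homo sapiens) for antiproliferative activity, read by MTT assay, with a stated time of 72 h; a higher number here means a weaker inhibitor of growth, a lower number a stronger inhibitor of growth. Compound 1 gives 490 nM, the lowest number of the three. The change methyl in place of hydrogen on a saturated chain carbon bound to an aromatic nitrogen produces a 5.8-fold higher number from compound 1 to compound 2 (0.76 log units; beyond the scatter). Compound 3 stands at 5290 nM, and against compound 2 this is a 1.9-fold higher number from compound 2 to compound 3 (0.27 log units; within the scatter). The difference between the core of compound 1 and the core of compound 3 is not broken down here.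

Compound 4 `CCCn1nc(-c2ccnc(Nc3ccc(O)cc3)n2)c2ccccc21` is not yet measured. It differs from compound 3 by methyl in place of hydrogen on a saturated chain carbon, two bonds along the chain from an aromatic nitrogen. For the measured compounds named here, this is the same kind of change as the one from compound 1 to compound 2, but not the same: there the methyl entered on a saturated chain carbon bound to an aromatic nitrogen, here it enters on a saturated chain carbon two bonds along the chain from an aromatic nitrogen. Going by the values given here, the earlier step is the only precedent, so the expected step from compound 3 to compound 4 is set at a 1.9-fold higher number from compound 3 to compound 4 (0.28 log units; within the scatter), somewhat smaller than the earlier one because a 5.8-fold higher number from compound 1 to compound 2 (0.76 log units; beyond the scatter) was already modest and the new carbon sits one bond further out. Compound 4 is therefore expected to give about 10000 nM in this assay, within 3500 nM to 30000 nM.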

Compound 4, concentration for 50% growth inhibition: 5450 nM
Compound 4: middle estimate off by 1.8-fold (0.26 log units), on the high side; the range from low to high includes it.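

In this assay, the ethyl to propyl step gives a 1.0-fold higher number from compound 3 to compound 4 (0.01 log units; within the scatter), so the loss seen on the earlier methyl to ethyl step does not carry over to the core of compound 3, and the two steps differ: the same change on two cores in this assay, a 5.8-fold higher number (0.76 log units; beyond the scatter) from compound 1 to compound 2 and a 1.0-fold higher number (0.01 log units; within the scatter) from compound 3 to compound 4, 5.6-fold (0.75 log units) apart, beyond the scatter of two such steps

On these two cases, the size of a methyl step cannot be transferred from one core to another in this series. What remains unresolved is the source of the gap, since the two steps differ both in the aryl group, 3-nitrophenyl in one and 4-hydroxyphenyl in the other, and in the place of the new methyl, on a saturated chain carbon bound to an aromatic nitrogen in one and two bonds along the chain from it in the other.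

Open, going by these compounds, is how a propyl chain reads with the 3-nitrophenyl group and a methyl with the 4-hydroxyphenyl group, the pairings that would separate these two differences. Also open, on these data alone, is whether a longer chain such as butyl, or a chain ending in an amine or a carboxylic acid, would stay as flat as the ethyl to propyl step.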